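Removing the methyl group from compound 1

The source may report more compounds than this note shows. Statements on the series, on what has been measured and on what is new or still open speak of the compounds shown alone.

Measured compounds:
compound 1, `Cc1cccc(-c2n[nH]cc2N2CCCNCC2)c1`: > 10000 nM
compound 2, `COc1ccccc1-c1n[nH]cc1N1CCCNCC1`: > 10000 nM

In an assay on isolated protein for binding affinity to 5-hydroxytryptamine receptor 4 (Homo sapiens) (a lower number here means a stronger inhibitor, a higher number a weaker inhibitor), compound 1 gives > 10000 nM, which is a limit of the assay and not a number. Compound 2 likewise returns only a limit in this assay, > 10000 nM. Among the compounds with values here, compound 1 therefore stands at the limit, as does the only other measured compound, summed up as the limit of > 10000 nM in this assay, at which 2 of the 2 values shown sit. Within the data shown here, no step between measured compounds is recorded, so no direction of change can be read from the data.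

Compound 3, `c1ccc(-c2n[nH]cc2N2CCCNCC2)cc1`, differs from compound 1 by hydrogen in place of methyl on an aromatic carbon. The expected step is a step that the limit leaves unreadable from compound 1 to compound 3, that is, nothing beyond the scatter, since the starting point is itself only a limit. Compound 3 is expected to remain at or close to the limit, with an estimate of 15000 nM and a range from 5000 nM to 50000 nM.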

Compound 3, inhibition constant: > 10000 nM
Compound 3 was reported as a limit; the forecaster's own chance of this, stated with the estimate: 80%; the middle value is on the limit's open side.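

In this assay compound 3 gives > 10000 nM, which is a limit of the assay and not a number. Within the data shown here, no step from compound 1 or compound 2 to compound 3 can be read. The compounds shown leave open whether any change on the shared core gives a value that is not a limit: the limit of > 10000 nM in this assay, at which 3 of the 3 values shown sit.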